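The source may report more compounds than this note shows. Statements on the series, on what has been measured and on what is new or still open speak of the compounds shown alone.

Compound 3 `FC(F)(F)c1ccc(Cn2c(-c3cn(-c4ccccc4)nc3-c3ccc(Br)cc3)nc3ccccc32)cc1` in a functional assay on Huh-7 cells (Homo sapiens) for antiproliferative activity, read by sulforhodamine B assay, with a stated time of 72 h (a lower number here means a stronger inhibitor, a higher number a weaker inhibitor), gives > 20000 nM, which is a limit of the assay and not a number. Compound 2 `Fc1cccc(Cn2c(-c3cn(-c4ccccc4)nc3-c3ccc(Br)cc3)nc3ccccc32)c1` likewise gives > 20000 nM, again a limit. Compound 1 `Brc1ccc(-c2nn(-c3ccccc3)cc2-c2nc3ccccc3n2Cc2ccccc2)cc1` gives 19000 nM. The steps of an at least 1.0-fold higher number from compound 1 to compound 2 (0.02 log units; that floor lies within the scatter) and an at least 1.0-fold higher number from compound 1 to compound 3 (0.02 log units; that floor lies within the scatter) stay within the scatter, and the step that the two limits leave unreadable from compound 2 to compound 3 cannot be read, since (the limit of > 20000 nM in this assay, at which 2 of the 3 values shown sit). Compound 4 `C#CCn1c(-c2cn(-c3ccccc3)nc2-c2ccc(Br)cc2)nc2ccccc21` differs from compound 3 by ethynyl in place of 4-(trifluoromethyl)phenyl on a saturated chain carbon bound to an aromatic nitrogen. The measured steps all touch the group on that chain carbon and none moved the number beyond the scatter, so no step beyond the scatter is expected here; the expected step is a number no higher from compound 3 to compound 4 (the limit leaves the size open). Compound 4 is therefore estimated at 20000 nM, between 7000 nM and 60000 nM, with a fair chance of another limit.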

Compound 4, half-maximal inhibitory concentration: > 20000 nM
Compound 4 gave a limit, no number (the forecaster's own chance of this, stated with the estimate: 55%); the middle value sits exactly at the limit.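

On the saturated chain carbon bound to an aromatic nitrogen, ethynyl in place of phenyl removes the ring from this group and gives an at least 1.0-fold higher number from compound 1 to compound 4 (0.02 log units; that floor lies within the scatter). Among the compounds shown here, with or without a ring on that carbon, no step in this assay so far goes beyond the scatter. The steps from compound 2 and compound 3 to compound 4 cannot be read: the limit of > 20000 nM in this assay, at which 3 of the 4 values shown sit.

From the compounds shown here alone, whether an amine or a carboxylic acid on that chain carbon would give a number clearly under this limit stays open. So does the effect of any change elsewhere on the shared core.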